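The source may report more compounds than this note shows. Statements on the series, on what has been measured and on what is new or still open speak of the compounds shown alone.

Compound 2 `O=c1cc(-n2cc(COc3ccccc3)nn2)c2cc(Br)ccc2o1` gives 1720 nM in a functional assay on MCF7 cells (Homo sapiens) for antiproliferative activity, read by MTT assay, with a stated time of 48 h (on this read-out higher numbers stand for weaker inhibition and lower numbers for stronger inhibition), the lowest of the two numbers recorded there. Its nearest neighbour is compound 3 `O=c1cc(-n2cc(COc3ccnc4ccc(Br)cc34)nn2)c2cc(Br)ccc2o1`, which gives 41600 nM in this assay. Compound 1 `O=c1cc(-n2cc(CNc3ccccc3)nn2)c2cc(Br)ccc2o1` gives only > 50000 nM in this assay, a limit of the assay rather than a number, as one of the values shown sits at the limit of > 50000 nM in this assay, at which 1 of the 3 values shown sits. Going by the values given here, the one measured step, an at least 29-fold lower number from compound 1 to compound 2 (1.46 log units; beyond the scatter), changed the atom that links the chain to the ring, not the substitution on the ring itself.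

Compound 4 `O=c1cc(-n2cc(COc3ccccc3O)nn2)c2cc(Br)ccc2o1` differs from compound 2 by hydroxy in place of hydrogen on an aromatic carbon. Among the compounds with values here, no measured step touches a substituent on that ring, so the step from compound 1 to compound 2 bears only loosely on it, and nothing in the data supports a change in this assay beyond the scatter in either direction. Compound 4 is therefore expected to give about 2500 nM in this assay, within a range of 800 nM to 8000 nM. The expected step is a 1.5-fold higher number from compound 2 to compound 4 (0.16 log units; within the scatter).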

Compound 4, half-maximal inhibitory concentration: 24800 nM
Compound 4: the middle estimate sits 9.9-fold (1.00 log units) below what was measured; the measured number lies above the stated range.
By their numbers in this assay, from the lowest: compound 2; then compounds 4 and 3 (each within the scatter of the next). At a limit, above all of these: compound 1.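

In this assay the ring of the phenoxy group proves sensitive to substitution: hydroxy in place of hydrogen, on an aromatic carbon ortho to a large group, brought a 14-fold higher number from compound 2 to compound 4 (1.16 log units; beyond the scatter) and thus a large loss. Against the anilino compound little of the advantage of compound 2 remains, as an at least 2.0-fold lower number from compound 1 to compound 4 (0.30 log units; that floor lies within the scatter) is all that can be read and that floor cannot be told from the scatter. This step has no firm size because compound 1 stands at a limit of the assay rather than at a number: the limit of > 50000 nM in this assay, at which 1 of the 4 values shown sits.

Going by these compounds, whether a methoxy group, a fluorine or an amine on that same aromatic carbon would raise the number as hydroxy does remains open. Also open, on these data alone, is how the number would respond to hydroxy elsewhere on this ring.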